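The compounds below may be only part of what the source reports. "The series", "measured", "known", "first", "only" and "open" are said of these compounds alone.

Measured in an in vitro assay on Sf9 cells for binding affinity to RAC-alpha serine/threonine-protein kinase (Homo sapiens), tested at 30 uM; on this read-out higher numbers stand for stronger stabilisation of the target against heat and lower numbers for weaker stabilisation of the target:
compound 1 `Nc1ncccc1-c1nc2cccnc2n1-c1ccc(NC(=O)c2ccccc2)cc1`: 7.3 degrees C
compound 2 `CC(=O)Nc1ccc(-n2c(-c3cccnc3N)nc3cccnc32)cc1`: 3.7 degrees C

Among the compounds with values here, compound 2 stands lowest of the two numbers; the nearest is compound 1, and the gap between them is the only measured step, a number 3.6 degrees C lower from compound 1 to compound 2 (beyond the scatter), which is beyond the scatter. That step concerns the substituent on the carbonyl carbon and nothing else.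

Compound 3 `CC(=O)NCc1ccc(-n2c(-c3cccnc3N)nc3cccnc32)cc1` differs from compound 2 by acetamidomethyl in place of acetamido on an aromatic carbon. Within the data shown here, the carbonyl substituent stays methyl, so the step from compound 1 to compound 2 does not bear on this change directly, and no measured pair shows it. Without a comparable step, the expected step is a number 0.20 degrees C lower from compound 2 to compound 3 (within the scatter), a change not expected to exceed the scatter in either direction, with the range kept wide. Compound 3 is estimated at 3.5 degrees C, between 1.5 degrees C and 5.5 degrees C.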

Compound 3, shift of the target's melting temperature: 2.3 degrees C
Compound 3: the middle estimate sits 1.2 degrees C above what was measured; low and high end bracket the measured number.
By their numbers in this assay, from the lowest: compound 3; then compound 2; then compound 1.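

In this assay, acetamidomethyl in place of acetamido on the aromatic carbon para to a large group gives a number 1.4 degrees C lower from compound 2 to compound 3 (beyond the scatter) and so shows that this position responds to a change in the link to the ring as well as to the substituent on the carbonyl carbon. Acetamidomethyl in place of benzamido gives a number 5.0 degrees C lower from compound 1 to compound 3 (beyond the scatter) as the largest step among the compounds shown, and compound 3 now holds the lowest number of the three. Nothing available here accounts for either step.

Still open, as far as these compounds go, is whether benzamidomethyl at this position would keep the higher number seen with benzamido or follow the fall seen with acetamidomethyl. Equally open, from the compounds shown here alone, is how a longer chain such as acetamidoethyl, a free aminomethyl or a carboxylic acid would read out on this carbon.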